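The source may hold more compounds than are shown below. What is called first, only, known or untested is meant among the compounds shown, and "the series" means these compounds.

Compounds measured so far in an ADME assay on HEK293-A cells (Homo sapiens) for cytotoxicity, read by MTT assay, with a stated time of 48 h; a lower number here means a stronger inhibitor, a higher number a weaker inhibitor:

Compound 1 `O=C1O[C@@H](CO)CN1c1ccc(-n2cc(-c3ccccn3)cn2)c(F)c1` gives > 400 ug/mL, which is a limit of the assay rather than a number.
Compound 2 `O=C1CSC(=O)N1C[C@H]1CN(c2ccc(-n3cc(-c4ccccn4)cn3)c(F)c2)C(=O)O1` gives 283 ug/mL.
Compound 3 `COC(=O)NC[C@H]1CN(c2ccc(-n3cc(-c4ccccn4)cn3)c(F)c2)C(=O)O1` gives 306 ug/mL.

Compound 3 stands highest of the two numbers in this assay, with compound 2 nearest; the step of a 1.1-fold higher number from compound 2 to compound 3 (0.03 log units; within the scatter) lies within the scatter, so the two are not to be ordered. The value of compound 1 is a limit only (the limit of > 400 ug/mL in this assay, at which 1 of the 3 values shown sits). The steps of an at least 1.4-fold lower number from compound 1 to compound 2 (0.15 log units; that floor lies within the scatter) and an at least 1.3-fold lower number from compound 1 to compound 3 (0.11 log units; that floor lies within the scatter) are floors whose size also lies within the scatter. All three compounds therefore sit in the same weakly cytotoxic region, and the three changes on the chain carbon bound to the ring carbon have not moved the number beyond the scatter.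

Compound 4 `NC(=O)[C@H]1CN(c2ccc(-n3cc(-c4ccccn4)cn3)c(F)c2)C(=O)O1` is not yet measured. The change is carbamoyl in place of ((methoxycarbonyl)amino)methyl on a saturated ring carbon. Among the compounds with values here, no measured step alters the group on the ring carbon itself; the nearest precedent is the set of chain changes above, all small. The expected step is a 1.1-fold higher number from compound 3 to compound 4 (0.03 log units; within the scatter), none beyond the scatter. Compound 4 is thus estimated at 330 ug/mL in this assay, with a range of 200 ug/mL to 550 ug/mL, and a fair chance that only a limit is reported.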

Compound 4, half-maximal inhibitory concentration: 152 ug/mL
Compound 4: middle estimate off by 2.2-fold (0.34 log units), on the high side; the whole stated range lies above it.
By their numbers in this assay, from the lowest: compounds 4, 2 and 3 (each within the scatter of the next). At a limit, above all of these: compound 1.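

In this assay, within the data shown here, carbamoyl on the saturated ring carbon next to the ring oxygen gives the only step that is printed as beyond the scatter, an at least 2.6-fold lower number from compound 1 to compound 4 (0.42 log units; beyond the scatter). That step is only a floor, since the value of compound 1 is a limit of the assay and not a number: the limit of > 400 ug/mL in this assay, at which 1 of the 4 values shown sits. Against the two compounds that carry a longer substituent at this position, the same group gives a 2.0-fold lower number from compound 3 to compound 4 (0.30 log units; within the scatter) and a 1.9-fold lower number from compound 2 to compound 4 (0.27 log units; within the scatter), so exchanging ((methoxycarbonyl)amino)methyl or (2,4-dioxo-1,3-thiazolidin-3-yl)methyl for carbamoyl does not separate compound 4 from compound 3 or compound 2.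

Still open, from the compounds shown here alone, is how large the step from compound 1 really is, and whether it belongs to carbamoyl itself or would follow from other replacements of hydroxymethyl on this ring carbon. A carboxylic acid or an aminomethyl group at this position, or a longer chain ending in carbamoyl, would test whether the step holds beyond this single pair.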